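This account rests on a few compounds, and the source may have more. Where it says the series, first, only, none or still open, it means among the compounds named here.

For the measured compounds named here, compound 1 `O=C(Nc1ccnnc1)c1cc(N2CCNCC2)ccc1OCc1ccccc1` is one of three compounds measured in an assay on Sf9 cells for inhibition of Leucine-rich repeat serine/threonine-protein kinase 2 (Homo sapiens), read by TR-FRET, with stated times of 30 min and 2 h; on this read-out lower numbers stand for stronger inhibition and higher numbers for weaker inhibition. In this assay compound 1 gives 15.9 nM. Compound 3 `O=C(Nc1cccc(Cl)c1)c1cc(C(F)(F)F)ccc1OCc1ccccc1` gives 25.1 nM, a number that lies within the usual scatter of that for compound 1, so the two cannot be told apart. Compound 2 `O=C(Nc1ccnnc1)c1cc(N2CCC(O)CC2)ccc1OCc1ccccc1` gives 39.8 nM, and the step of a 2.5-fold higher number from compound 1 to compound 2 (0.40 log units; beyond the scatter) is the only one here that separates two compounds beyond the scatter.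

Compound 4 `CN1CCN(c2ccc(OCc3ccccc3)c(C(=O)Nc3ccnnc3)c2)CC1` differs from compound 1 by one change: methyl in place of hydrogen on an amine nitrogen in a ring. Going by the values given here, the only measured step that touches the same ring of compound 1 is a 2.5-fold higher number from compound 1 to compound 2 (0.40 log units; beyond the scatter), which replaced the whole ring, a larger change than adding a methyl. Among the compounds with values here, no measured pair shows the effect of a methyl on an amine nitrogen in a ring, so there is no direct guide.

Given the small size of the change, a step no larger than the scatter is expected, a 1.3-fold higher number from compound 1 to compound 4 (0.10 log units; within the scatter). For compound 4 in this assay the estimated value is 20 nM, with a range from 8 nM to 50 nM.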

Compound 4, half-maximal inhibitory concentration: 12.6 nM
Estimate against measurement, compound 4: 1.6-fold (0.20 log units) above; low and high end bracket the measured number.
By their numbers in this assay, from the lowest: compounds 4, 1, 3 and 2 (each within the scatter of the next, the first and the last beyond it).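

Adding a methyl to the amine nitrogen gives a 1.3-fold lower number from compound 1 to compound 4 (0.10 log units; within the scatter) in this assay, so this nitrogen can carry a methyl without a shift that can be told from the scatter. Replacing the whole ring is a different matter: with 4-methylpiperazin-1-yl in place of 4-hydroxypiperidin-1-yl, the result is a 3.2-fold lower number from compound 2 to compound 4 (0.50 log units; beyond the scatter) and compound 2 now stands apart from both the piperazin-1-yl and the 4-methylpiperazin-1-yl compounds, not from just one. Nothing given here accounts for either step.

The compounds shown carry only hydrogen or methyl on this nitrogen, so they do not tell how far this acceptance of a substituent extends. An ethyl group, a longer chain ending in an amine, or an acetyl group at the same place could give a quite different number.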